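Aryl swap on the pyrazolone nitrogen in a hydroxamate series

The source may hold more compounds than are shown below. What is called first, only, known or untested is meant among the compounds shown, and "the series" means these compounds.

Three compounds carry a hydroxamic acid chain on a shared core and an aryl group on an aromatic nitrogen. Compound 1 `COc1cc2c(Oc3ccc(NC(=O)c4nn(-c5ccccc5)cc(C)c4=O)cc3F)ccnc2cc1OCCCCCC(=O)NO` gives 690 nM in a functional assay on HCT-116 cells (Homo sapiens) for inhibition, read by MTT assay, with a stated time of 72 h; a higher number here means a weaker inhibitor, a lower number a stronger inhibitor. Compound 2 `COc1cc2c(Oc3ccc(NC(=O)c4nn(-c5cccc(C)c5)cc(C)c4=O)cc3)ccnc2cc1OCCCCCCC(=O)NO` gives 370 nM in this assay. Compound 3 `COc1cc2c(Oc3ccc(NC(=O)c4nn(-c5ccc(C)cc5C)cc(C)c4=O)cc3)ccnc2cc1OCCCCCCC(=O)NO` gives 440 nM in this assay. Compound 3 stands with the second highest of the three numbers; its nearest neighbour is compound 2 and its furthest is compound 1, and both distances are within the scatter.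

Among the compounds with values here, the one step measured at the aryl position, a 1.2-fold higher number from compound 2 to compound 3 (0.08 log units; within the scatter), is within the scatter. Compound 4 `COc1cc2c(Oc3ccc(NC(=O)c4nn(-c5ccc(F)c(Cl)c5)cc(C)c4=O)cc3)ccnc2cc1OCCCCCCC(=O)NO` is the next member: 3-chloro-4-fluorophenyl in place of 2,4-dimethylphenyl on an aromatic nitrogen. Within the data shown here, no measured step bears on a halogen-bearing aryl group here; the only evidence is that changing the methyl pattern on this ring, as in the step from compound 2 to compound 3, did not move this assay beyond the scatter, and compound 1 with a different chain and a plain phenyl sits within the scatter of both.

For compound 4 the expectation is therefore no step beyond the scatter, a 1.0-fold lower number from compound 3 to compound 4 (0.02 log units; within the scatter), and an estimated 420 nM in this assay, with a range from 200 nM to 900 nM.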

Compound 4, half-maximal inhibitory concentration: 370 nM
For compound 4 the middle estimate is 1.1-fold (0.06 log units) above the measured one, and the stated range covers the measured number.
By their numbers in this assay, from the lowest: compounds 2, 4, 3 and 1 (each within the scatter of the next).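

In this assay, within the data shown here, 3-chloro-4-fluorophenyl is the first halogen-bearing aryl group at this position to be read against the methyl-substituted rings: the swap gives a 1.2-fold lower number from compound 3 to compound 4 (0.08 log units; within the scatter) and, against 3-methylphenyl, no change at the digits printed from compound 2 to compound 4 (within the scatter). Compounds 2, 3 and 4 therefore read alike at this position, and the range of aryl groups that stay within the scatter now extends from methyl patterns to a ring bearing both chlorine and fluorine, with no compound among these three going against it. Nothing measured here accounts for this flat reading, and no independent data on these aryl groups accompany the numbers.

Compound 1 differs from the others in more than one place, so its steps to them cannot be read, and the effect of the plain phenyl stays separate and unknown, as do the effects of the ring fluorine and the chain length. Going by these compounds, whether any group on this aryl ring moves the number beyond the scatter also stays open, for instance a primary amine or a carboxylic acid in place of the chlorine and fluorine.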